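The source may report more compounds than this note shows. Statements on the series, on what has been measured and on what is new or still open speak of the compounds shown alone.

Of the compounds shown here, three built on one shared core have been measured in an assay on isolated protein for agonist activity at Bile acid receptor (Homo sapiens), read by FRET; on this read-out lower numbers stand for an effect already at smaller amounts and higher numbers for an effect only at larger amounts of compound. Compound 1 `CN(Cc1cccc(C(=O)O)c1)c1ccc(OCc2c(-c3c(Cl)cccc3Cl)noc2C2CC2)nc1C(F)(F)F` carries a (3-carboxybenzyl)(methyl)amino group on an aromatic carbon of that core, and compound 1 gives 3 nM. Compound 2 `CC(Nc1ccc(C(=O)O)cc1)c1ccc(OCc2c(-c3c(Cl)cccc3Cl)noc2C2CC2)nc1C(F)(F)F` carries 1-((4-carboxyphenyl)amino)ethyl in the same place, and compound 2 gives 101 nM. Compound 3 `O=C(O)c1ccccc1OCc1ccc(OCc2c(-c3c(Cl)cccc3Cl)noc2C2CC2)nc1C(F)(F)F` carries (2-carboxyphenoxy)methyl there, and compound 3 gives 434 nM, the highest of the three numbers. The measured steps are a 34-fold higher number from compound 1 to compound 2 (1.53 log units; beyond the scatter), a 140-fold higher number from compound 1 to compound 3 (2.16 log units; beyond the scatter) and a 4.3-fold higher number from compound 2 to compound 3 (0.63 log units; beyond the scatter).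

Compound 4 `O=C(O)c1cccc(OCc2ccc(OCc3c(-c4c(Cl)cccc4Cl)noc3C3CC3)nc2C(F)(F)F)c1` has not yet been measured. It differs from compound 3 by 3-carboxyphenyl in place of 2-carboxyphenyl on an oxygen on a saturated carbon. Within the data shown here, no measured step changes only where the carboxy group sits on this ring; the steps from compound 1 and from compound 2 to compound 3 each alter the whole linker as well, so they bear on the change only loosely. Compound 1, whose ring is likewise a 3-carboxyphenyl, gives 3 nM, the lowest number of the set, while compound 3, whose ring is a 2-carboxyphenyl, stands at the other end. On that slender basis a modest lowering of the number is expected for compound 4, as a 2.9-fold lower number from compound 3 to compound 4 (0.46 log units; beyond the scatter). The estimate for compound 4 in this assay is 150 nM, with a range from 40 nM to 600 nM.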

Compound 4, half-maximal effective concentration: 43 nM
For compound 4 the middle estimate is 3.5-fold (0.54 log units) above the measured one; low and high end bracket the measured number.
By their numbers in this assay, from the lowest: compound 1; then compound 4; then compound 2; then compound 3.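

In this assay, among these compounds, a 10-fold lower number from compound 3 to compound 4 (1.00 log units; beyond the scatter) is the first step in the set that changes only where the carboxy group sits, with the linker held constant, and it shows that on this oxygen the number depends clearly on that placement, with 3-carboxyphenyl favoured over 2-carboxyphenyl. With 3-carboxyphenyl in place, the (3-carboxyphenoxy)methyl group moves ahead of 1-((4-carboxyphenyl)amino)ethyl, as a 2.3-fold lower number from compound 2 to compound 4 (0.37 log units; beyond the scatter) shows, yet it stays well behind (3-carboxybenzyl)(methyl)amino, as a 14-fold higher number from compound 1 to compound 4 (1.16 log units; beyond the scatter) shows, so sharing the 3-carboxyphenyl ring with compound 1 does not alone reach the number of compound 1, and the two groups still differ in the chain that carries that ring. No supporting data accompany these values to explain why either change has the size it does.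

Going by these compounds, it remains open how a 4-carboxyphenyl ring on the same oxygen would compare with the 3-carboxyphenyl of compound 4. Also open, on these data alone, is whether a methylamino link in place of the oxygen, with the ring unchanged, would close the remaining distance to compound 1, and whether a tetrazole could stand in for the carboxylic acid.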